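Bromo in place of thiophen-2-yl on the shared core

A few compounds are considered here, and "the series" means these few. Any claim that something is new, unique, unknown or untested is made for them only; others in the source may bear on it.

In an ADME assay on HEL cells (Homo sapiens) for cytotoxicity, with a stated time of 3 days (a lower number here means that less compound is tolerated, a higher number that more compound is tolerated), compound 1 `Cc1cc(I)cn2c(CSCCc3ccccc3)cnc12` gives only a limit, > 50 ug/mL. Going by the values given here, compound 2 `Cc1cc(-c2cccs2)cn2c(CSCCc3ccccc3)cnc12` gives 32 ug/mL, the only actual number so far. Compound 3 `Cc1cc(Br)cn2c(CSCCc3ccccc3)cnc12` has bromo in place of thiophen-2-yl on an aromatic carbon. Among the compounds with values here, one measured step bears on this change, the swap of iodo for thiophen-2-yl, an at least 1.5-fold lower number from compound 1 to compound 2 (0.19 log units; that floor lies within the scatter). On these data alone, its true size stays open, as the reading is capped by the limit of > 50 ug/mL in this assay, at which 1 of the 2 values shown sits. Reversing that swap with bromo, a small expected step towards a higher number in this assay is a 1.6-fold higher number from compound 2 to compound 3 (0.19 log units; within the scatter). Compound 3 is estimated at 50 ug/mL, with an expected range of 28 ug/mL to 100 ug/mL.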

Compound 3, half-maximal cytotoxic concentration: 28 ug/mL
Beside the measured number, compound 3's estimate is 1.8-fold (0.25 log units) above it; low and high end bracket the measured number.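

In this assay, this position on an aromatic carbon does not separate bromo from thiophen-2-yl (a 1.1-fold lower number from compound 2 to compound 3 (0.06 log units; within the scatter)), although one group has 1 heavy atom and the other 5 heavy atoms with a five-membered aromatic ring. Compound 3 also gives the second actual number in the series, so the swap away from iodo can now be read with bromo as well (an at least 1.7-fold lower number from compound 1 to compound 3 (0.25 log units; that floor lies within the scatter)). On these data alone, the true size of that step stays open because of a limit: the limit of > 50 ug/mL in this assay, at which 1 of the 3 values shown sits.

As far as these compounds go, whether any group at this position moves the number beyond the scatter remains open. An amine or a carboxylic acid here could answer that, as neither is among the compounds shown.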